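Adding a Methoxy Group on Two Related Cores

This account rests on a few compounds, and the source may have more. Where it says the series, first, only, none or still open, it means among the compounds named here.

Compound 1 `C=C(Br)C(=O)Nc1ccc(/C=C/C(=O)c2ccccc2)cc1` gives 3900 nM in a functional assay on FM3A cells (Mus musculus) for antiproliferative activity, with a stated time of 48 h; a higher number here means a weaker inhibitor, a lower number a stronger inhibitor. Compound 2 `C=C(Br)C(=O)Nc1ccc(/C=C/C(=O)c2ccc(OC)cc2)cc1` differs from it only by methoxy in place of hydrogen on an aromatic carbon, and in this assay compound 2 gives 1200 nM; that is a 3.3-fold lower number from compound 1 to compound 2 (0.51 log units; beyond the scatter). Compound 3 `C=C(Br)C(=O)Nc1ccc(C(=O)/C=C/c2ccccc2)cc1` is built from the same atoms as compound 1 joined differently; the difference between the two cores is not broken down here. In this assay compound 3 gives 690 nM. For the measured compounds named here, compound 4 `C=C(Br)C(=O)Nc1ccc(C(=O)/C=C/c2ccc(OC)cc2)cc1` differs from compound 3 by methoxy in place of hydrogen on an aromatic carbon, the same change, at the same place, as the one from compound 1 to compound 2. Going by the values given here, compound 4 is expected to show a 2.8-fold lower number from compound 3 to compound 4 (0.44 log units; beyond the scatter), an expectation resting on the single earlier instance of this change, a 3.3-fold lower number from compound 1 to compound 2 (0.51 log units; beyond the scatter). Compound 4 is therefore estimated at 250 nM, with a likely range from 100 nM to 700 nM.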

Compound 4, half-maximal inhibitory concentration: 1000 nM
Compound 4: middle estimate off by 4.0-fold (0.60 log units), on the low side; measured number outside the range, above it.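

On the core of compound 3, methoxy in place of hydrogen on an aromatic carbon gives a 1.4-fold higher number from compound 3 to compound 4 (0.16 log units; within the scatter), so in this assay the two compounds cannot be told apart. The change does not carry over from one core to the other at the same size: the same change on two cores in this assay, a 3.3-fold lower number (0.51 log units; beyond the scatter) from compound 1 to compound 2 and a 1.4-fold higher number (0.16 log units; within the scatter) from compound 3 to compound 4, 4.7-fold (0.67 log units) apart, beyond the scatter of two such steps. A step seen on one of these cores is therefore a poor guide to the other, but two cores cannot show why they differ or how a further core would respond.

The compounds shown leave open whether other groups in place of that hydrogen, such as chlorine, an amine or a longer ethoxy chain, would also differ between the two cores.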